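Methyl on an aromatic nitrogen: working notes on the series

The source may hold more compounds than are shown below. What is called first, only, known or untested is meant among the compounds shown, and "the series" means these compounds.

In an ADME assay on CHO cells (Cricetulus griseus) for cytotoxicity, read by LDH release (a higher number here means a weaker inhibitor, a lower number a stronger inhibitor), compound 1 (`CCC(NC(=O)C(C)Oc1ccc(Cl)cc1Cl)c1ccc(F)cc1`) gives > 100000 nM as a limit of the assay. Compound 2 (`CC(Oc1ccc(Cl)cc1Cl)C(=O)NC(CO)c1ccc(F)cc1`) gives a true number of 18000 nM in this assay. Compound 3 (`CC(Oc1ccc(Cl)cc1Cl)C(=O)NCc1ccc2[nH]ccc2c1`) gives > 100000 nM in this assay and this is also a limit. The position of compound 3 therefore rests on the limit of > 100000 nM in this assay, at which 2 of the 3 values shown sit, and no number exists for it.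

Compound 4 (`CC(Oc1ccc(Cl)cc1Cl)C(=O)NCc1ccc2c(ccn2C)c1`) differs from compound 3 as follows: methyl in place of hydrogen on an aromatic nitrogen. Among the measured compounds shown here, the one measured step, an at least 5.5-fold lower number from compound 1 to compound 2 (0.74 log units; beyond the scatter), is hydroxy in place of methyl on a saturated chain carbon. It shows that a single change can move a compound off the limit, but it is a different change in a different place. For the measured compounds named here, no measured step involves methyl in place of hydrogen on an aromatic nitrogen, so no direction is favoured and no change beyond the scatter is expected. The expected step is a number no higher from compound 3 to compound 4 (the limit leaves the size open). Compound 4 is estimated at 100000 nM (expected range 40000 nM to 250000 nM) and another limit reading is likely.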

Compound 4, half-maximal inhibitory concentration: 6300 nM
Beside the measured number, compound 4's estimate is 16-fold (1.20 log units) above it, and the stated range ends above it.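

In this assay, methyl in place of hydrogen on an aromatic nitrogen gives an at least 15-fold lower number from compound 3 to compound 4 (1.20 log units; beyond the scatter), so this nitrogen of the five-membered aromatic ring is a place where one added carbon moves the read-out well beyond the scatter. This is a second, separate single change that leads away from the limit, after an at least 5.5-fold lower number from compound 1 to compound 2 (0.74 log units; beyond the scatter), and it lies in a different place on a different compound. Compound 3 has a limit and not a number, so the step has a lower bound but no exact size: the limit of > 100000 nM in this assay, at which 2 of the 4 values shown sit.

Going by these compounds, what an ethyl group, a longer chain or a carboxylic acid on this same nitrogen would do remains open. On these data alone, the step rests on one pair of compounds, so whether it would carry over to another core is also open.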